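Shortening a benzyl ether to a phenyl ether

The source may report more compounds than this note shows. Statements on the series, on what has been measured and on what is new or still open speak of the compounds shown alone.

Measured so far:
- compound 1, `CCCc1c(OCCCOc2cc(O)c(C(C)=O)cc2CC)cccc1OCc1ccccc1C(=O)O`: 130 nM
- compound 2, `CCCc1cc(Oc2ccc(C(=O)O)cc2)ccc1OCCCOc1cc(O)c(C(C)=O)cc1CC`: 330 nM

Of the compounds shown here, two share a core and have been tested. In an assay on isolated protein for inhibition of leukotriene B4 receptor (Homo sapiens) (a higher number here means a weaker inhibitor, a lower number a stronger inhibitor), compound 1 gives 130 nM, the lower of the two numbers, so the stronger inhibitor of the pair. In this assay compound 2 gives 330 nM, a higher number that lies beyond the usual scatter of repeated measurements.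

Compound 3, `CCCc1c(OCCCOc2cc(O)c(C(C)=O)cc2CC)cccc1Oc1ccccc1C(=O)O`, has not yet been measured. It differs from compound 1 in one place: 2-carboxyphenyl in place of 2-carboxybenzyl on an oxygen on an aromatic ring. For the measured compounds named here, no pair of measured compounds shows a change of this kind, so its effect cannot be read from the data; only a small step, inside or just beyond the scatter, is expected, with no firm direction. The step from compound 1 to compound 3 is estimated at a 1.5-fold higher number from compound 1 to compound 3 (0.19 log units; within the scatter). Compound 3 is expected to give 200 nM, within a range from 60 nM to 700 nM.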

Compound 3, half-maximal inhibitory concentration: 24 nM
For compound 3 the middle estimate is 8.3-fold (0.92 log units) above the measured one; measured number outside the range, below it.
By their numbers in this assay, from the lowest: compound 3; then compound 1; then compound 2.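

In this assay, putting 2-carboxyphenyl in place of 2-carboxybenzyl on an oxygen on an aromatic ring gives a 5.4-fold lower number from compound 1 to compound 3 (0.73 log units; beyond the scatter), a step beyond the usual scatter. This position therefore responds strongly to a small edit: the two groups have the same kind of ring and the same counts of hydrogen-bond donors and acceptors, and the entering group has 7 carbon atoms against 8 in the group that leaves. Nothing available here explains why the shorter group gives the stronger inhibitor.

This single pair cannot show how far the trend runs, such as whether a longer chain like 2-carboxyethyl on the same oxygen would weaken inhibition further. It also leaves open whether a tetrazole could stand in for the carboxylic acid of compound 3 and keep its strength.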